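PLK1 inhibitor series: amide substituent change

The compounds below may be only part of what the source reports. "The series", "measured", "known", "first", "only" and "open" are said of these compounds alone.

Measured so far:
compound 1, `COc1cc(C(=O)NC2CCN(C)CC2)ccc1Nc1ncc2c(n1)N(C1CCCC1)[C@H](C)C(=O)N2C`: 1.1 nM
compound 2, `CCC[C@@H]1C(=O)N(C)c2cnc(Nc3ccc(C(=O)NC4CCN(C)CC4)cc3OC)nc2N1C1CCCC1`: 9.9 nM

In an assay on isolated protein for inhibition of serine/threonine-protein kinase PLK1 (Homo sapiens), read by Z'-LYTE (on this read-out higher numbers stand for weaker inhibition and lower numbers for stronger inhibition), compound 1 gives the lowest of the two numbers; its nearest neighbour is compound 2 (a 9.0-fold higher number from compound 1 to compound 2 (0.95 log units; beyond the scatter)). Compound 3, `COc1cc(C(=O)NC2=CCN(C)C=C2)ccc1Nc1ncc2c(n1)N(C1CCCC1)[C@H](C)C(=O)N2C`, differs from compound 1 by a group of 7 heavy atoms (6 carbon, 1 nitrogen; one six-membered non-aromatic ring with 1 hetero atom) in place of a group of 7 heavy atoms (6 carbon, 1 nitrogen; one six-membered non-aromatic ring with 1 hetero atom), on an amide-type nitrogen. Within the data shown here, the only measured step, a 9.0-fold higher number from compound 1 to compound 2 (0.95 log units; beyond the scatter), concerns a different site, the saturated chain carbon, and so gives no direct guidance here. Among the measured compounds shown here, with no step at the amide nitrogen to lean on, a change of modest size is expected at most, a 2.3-fold higher number from compound 1 to compound 3 (0.36 log units; beyond the scatter). Compound 3 is estimated at 2.5 nM, range 0.8 nM to 10 nM.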

Compound 3, half-maximal inhibitory concentration: 8.4 nM
Compound 3: middle estimate off by 3.4-fold (0.53 log units), on the low side, and the stated range covers the measured number.
By their numbers in this assay, from the lowest: compound 1; then compounds 3 and 2 (each within the scatter of the next).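

In this assay, the amide-type nitrogen proves sensitive to a change that leaves the heavy-atom count untouched: replacing 1-methylpiperidin-4-yl with a ring carrying 2 double bonds outside aromatic rings gives a 7.6-fold higher number from compound 1 to compound 3 (0.88 log units; beyond the scatter). Hydrogen-bond donor and acceptor counts and net charge are the same for both groups, yet the number still moves. No measurement at hand explains this step. Open, from the compounds shown here alone, is how a piperidin-4-yl without the methyl, a 1-ethylpiperidin-4-yl or a cyclohexyl on this nitrogen would compare with compound 1. Also open, going by these compounds, is whether the step holds with the longer chain of compound 2.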